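A few compounds are considered here, and "the series" means these few. Any claim that something is new, unique, unknown or untested is made for them only; others in the source may bear on it.

Compound 1 `C#CCN(C)CCCCCOc1ccc2c(c1)CCC2=O` and compound 2 `C#CCN(C)CCCCCCOc1ccc2c(c1)CCC2=O` share one core, while compound 3 `C#CCN(C)CCCCOc1ccc(C=O)c(OC)c1` and the unmeasured compound 4 `C#CCN(C)CCCCCOc1ccc(C=O)c(OC)c1` share another; the difference between the two cores is not broken down here. In an ADME assay on BTI cells for inhibition of Amine oxidase [flavin-containing] A (Homo sapiens), read by fluorescence and Amplex Red, with a stated time of 15 min, tested at 100 uM (on this read-out lower numbers stand for less inhibition and higher numbers for more inhibition at the one concentration tested (going by the name of the read-out)), compound 1 gives 31%, and compound 2 gives 4.42%, so the change (methyl(propargyl)amino)methyl in place of methyl(propargyl)amino on a saturated chain carbon, five bonds along the chain from an oxygen on an aromatic ring brought a number 26.6 percentage points lower from compound 1 to compound 2 (beyond the scatter). Compound 3 gives 29.4% in this assay, within the scatter of compound 1. The change to compound 4 is (methyl(propargyl)amino)methyl in place of methyl(propargyl)amino on a saturated chain carbon, four bonds along the chain from an oxygen on an aromatic ring, the same kind of change, though here it sits four bonds along the chain from the oxygen rather than five. Because compound 1 to compound 2 gave a number 26.6 percentage points lower from compound 1 to compound 2 (beyond the scatter), a similar drop is expected, a number 21.4 percentage points lower from compound 3 to compound 4 (beyond the scatter). Compound 4 is therefore estimated at 8%, between 0% and 22%.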

Compound 4, a percentage reported as inhibition, at one concentration (the size of the read-out at that concentration, not a potency): 27.1%
Beside the measured number, compound 4's estimate is 19.1 percentage points below it; the measured number lies above the stated range.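

In this assay, putting (methyl(propargyl)amino)methyl in place of methyl(propargyl)amino brought a number 2.3 percentage points lower from compound 3 to compound 4 (within the scatter). The change therefore does not carry over at one size between these two cores: the same change on two cores in this assay, a number 26.6 percentage points lower (beyond the scatter) from compound 1 to compound 2 and a number 2.3 percentage points lower (within the scatter) from compound 3 to compound 4, 24.3 percentage points apart, beyond the scatter of two such steps. This shows that the drop seen on the core of compound 1 cannot be assumed on the core of compound 3, but with a single pair on each core it does not show which part of the cores makes the difference.

Going by these compounds, whether a longer chain, such as 2-(methyl(propargyl)amino)ethyl, would bring a clear drop on the core of compound 3 stays open. So does the size of this change on any third core.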